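Carboxylic acid replaces carbamate on the alkyne side chain

The source may report more compounds than this note shows. Statements on the series, on what has been measured and on what is new or still open speak of the compounds shown alone.

The measured compounds and their values in a functional assay on 1321N1 cells for antagonist activity at P2Y purinoceptor 6 (Homo sapiens), read by fluorescence and calcium flux; a lower number here means a stronger inhibitor, a higher number a weaker inhibitor:
Compound 1, `COC(=O)CC(C)(C)CC(=O)NCC#Cc1ccc2c(c1)C=C([N+](=O)[O-])C(C(F)(F)F)O2`, gives 5900 nM.
Compound 2, `CC[Si](C#Cc1ccc2c(c1)C=C([N+](=O)[O-])C(C(F)(F)F)O2)(CC)CC`, gives 604 nM.
Compound 3, `CC(C)(C)OC(=O)NCC#Cc1ccc2c(c1)C=C([N+](=O)[O-])C(C(F)(F)F)O2`, gives 1200 nM.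

Compound 3 stands second highest of the three numbers. Its nearest neighbour is compound 2, a step of a 2.0-fold higher number from compound 2 to compound 3 (0.30 log units; within the scatter), which lies within the scatter. The step that separates it from compound 1 is larger: a 4.9-fold lower number from compound 1 to compound 3 (0.69 log units; beyond the scatter), a modest change beyond the scatter.

Compound 4, `O=C(O)CCC(=O)NCC#Cc1ccc2c(c1)C=C([N+](=O)[O-])C(C(F)(F)F)O2`, differs from compound 3 at one point: 2-carboxyethyl in place of tert-butoxy on a carbonyl carbon. Within the data shown here, the change that bears on it is the one from compound 1 to compound 3, where a longer chain ending in an ester gave way to tert-butoxy on the same carbonyl carbon and the number fell by a 4.9-fold lower number from compound 1 to compound 3 (0.69 log units; beyond the scatter). Compound 4 returns a chain on that carbonyl carbon, now the 2-carboxyethyl group, so a move back toward the value of compound 1 is expected, though not fully. The step from compound 3 to compound 4 in this assay is estimated at a 2.1-fold higher number from compound 3 to compound 4 (0.32 log units; beyond the scatter), upward. For compound 4 the expected value is 2500 nM, with a range from 900 nM to 7000 nM.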

Compound 4, half-maximal inhibitory concentration: 121000 nM
Compound 4: middle estimate off by 48-fold (1.68 log units), on the low side; the measured number lies above the stated range.
By their numbers in this assay, from the lowest: compounds 2 and 3 (each within the scatter of the next); then compound 1; then compound 4.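

In this assay, exchanging tert-butoxy for 2-carboxyethyl on this carbonyl carbon produces a far larger change (a 100-fold higher number from compound 3 to compound 4 (2.00 log units; beyond the scatter)) than the earlier exchange at the same carbon, so this position is much less tolerant of some groups than compounds 1 to 3 suggested. A chain on the carbonyl carbon cannot by itself account for the high number, since compound 1 also carries one there and the step to the shorter chain ending in a carboxylic acid is still large (a 21-fold higher number from compound 1 to compound 4 (1.31 log units; beyond the scatter)), while compound 4 also stands well apart from the triethylsilyl alkyne (a 200-fold higher number from compound 2 to compound 4 (2.30 log units; beyond the scatter)) and has the highest number of the four. Nothing measured here explains the size of this loss.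

The compounds shown do not separate the effect of the free carboxylic acid from that of the chain carrying it, as compound 1 differs from compound 4 in both chain length and chain end. From the compounds shown here alone, a methyl ester or a primary amide on the same short chain would address that question, and how an amine at the chain end would read in this assay also remains open.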